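The source may hold more compounds than are shown below. What is called first, only, known or untested is meant among the compounds shown, and "the series" means these compounds.

Measured compounds in a functional assay on the whole organism with Mus musculus as the target, in the maximal electroshock model; a higher number here means that more compound is needed for the effect, a lower number that less compound is needed:

- compound 1 `Clc1ccc(N2N=NCC2c2ccncc2)cc1`: 257 mg/kg
- compound 2 `FC(F)(F)c1ccc(N2N=NCC2c2ccncc2)cc1`: 689 mg/kg
- compound 3 `Clc1ccc(-n2nncc2-c2cccnc2)cc1`: 65.8 mg/kg

Compound 3 gives the lowest of the three numbers in this assay. Its nearest neighbour is compound 1 with 257 mg/kg, and compound 2 with 689 mg/kg lies furthest away; both gaps are beyond the scatter.

Compound 4 `c1ccc(-n2nncc2-c2cccnc2)cc1` is not yet measured. It differs from compound 3 in one place: hydrogen in place of chloro on an aromatic carbon.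

For the measured compounds named here, no measured step removes a chloro group altogether. Going by the values given here, the only step available on a related position is a 2.7-fold higher number from compound 1 to compound 2 (0.43 log units; beyond the scatter), which swaps one substituent for another on the core of compound 1 and is modest in size. It does not show what removal of the group does, and compound 3 carries a different core. The expectation for compound 4 is therefore a step of modest size or none beyond the scatter, with the direction uncertain; compound 4 is expected to show a 1.5-fold higher number from compound 3 to compound 4 (0.18 log units; within the scatter), the unsubstituted ring being taken to need somewhat more compound than compound 3.

The estimate for compound 4 in this assay is 100 mg/kg, with a range from 45 mg/kg to 220 mg/kg.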

Compound 4, dose for half-maximal effect: 76.4 mg/kg
Beside the measured number, compound 4's estimate is 1.3-fold (0.12 log units) above it; measured number inside the range.
By their numbers in this assay, from the lowest: compounds 3 and 4 (each within the scatter of the next); then compound 1; then compound 2.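

In this assay, for the compounds shown here, hydrogen in place of chloro on an aromatic carbon, para to a large group, gives a 1.2-fold higher number from compound 3 to compound 4 (0.06 log units; within the scatter) and is the first direct reading of what losing the chloro group does. The earlier step, a 2.7-fold higher number from compound 1 to compound 2 (0.43 log units; beyond the scatter), showed only that trifluoromethyl in place of chloro matters on the core of compound 1, and it gave no reading of removal or of the core of compound 3. On the core of compound 3, the chloro group is therefore not needed to keep the number within the scatter, and no information on the cause of this is available.

The compounds shown leave open whether hydrogen in place of chloro would also stay within the scatter on the core of compound 1, and whether trifluoromethyl in place of chloro on the core of compound 3 would repeat the step seen on the core of compound 1. They also leave open how this position responds to a different kind of group, such as an amine, a carboxylic acid or a longer chain.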